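This account rests on a few compounds, and the source may have more. Where it says the series, first, only, none or still open, it means among the compounds named here.

Compound 1 `O=C(Cn1ccnc1)N1CCC(NS(=O)(=O)c2cc(S(=O)(=O)c3ccccc3)ccc2C(F)(F)F)CC1` gives 30 nM in an assay on isolated protein for binding affinity to secreted frizzled-related protein 1 (Homo sapiens), read by fluorescence; a higher number here means a weaker inhibitor, a lower number a stronger inhibitor. Compound 2 `CN(C)C(=O)N1CCC[C@H]1C(=O)N1CCC(NS(=O)(=O)c2cc(S(=O)(=O)c3ccccc3)ccc2C(F)(F)F)CC1` gives 30 nM in this assay.

Compound 2 stands level with compound 1 at the digits shown: the step of no change at the digits printed from compound 1 to compound 2 (within the scatter) lies within the usual scatter, although the group on the carbonyl carbon was exchanged for a different one there.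

Compound 3 `O=C([C@@H]1CCCN1Cc1ccccc1)N1CCC(NS(=O)(=O)c2cc(S(=O)(=O)c3ccccc3)ccc2C(F)(F)F)CC1` follows from compound 2 by one change, (benzyl in place of dimethylcarbamoyl on an amine nitrogen in a ring), benzyl in place of dimethylcarbamoyl on an amine nitrogen in a ring. Within the data shown here, the only step that bears on this is the one from compound 1 to compound 2, which changed the same outer part of the molecule and stayed within the scatter in this assay. From that one step the outer region appears tolerant of exchange, so for compound 3 no step beyond the scatter is expected, and the estimated step is no change at the digits printed from compound 2 to compound 3 (within the scatter). Among the measured compounds shown here, only one prior step supports this, so the range is kept wide. Compound 3 is therefore expected to give about 30 nM in this assay, with a range from 10 nM to 100 nM.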

Compound 3, half-maximal inhibitory concentration: 1400 nM
For compound 3 the middle estimate is 47-fold (1.67 log units) below the measured one; measured number above the stated range.
By their numbers in this assay, from the lowest: compounds 1 and 2 (each within the scatter of the next); then compound 3.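

In this assay, among these compounds, replacing dimethylcarbamoyl with benzyl on the amine nitrogen in the five-membered non-aromatic ring gives a 47-fold higher number from compound 2 to compound 3 (1.67 log units; beyond the scatter), whereas the only earlier step, no change at the digits printed from compound 1 to compound 2 (within the scatter), had left the number unchanged at the digits printed. The wider exchange on the carbonyl carbon gives a 47-fold higher number from compound 1 to compound 3 (1.67 log units; beyond the scatter), so this outer part of the molecule accepts 1-(dimethylcarbamoyl)pyrrolidin-2-yl and (1H-imidazol-1-yl)methyl alike but not 1-benzylpyrrolidin-2-yl, and the group on that ring nitrogen clearly matters to the reading. No measurement presented here accounts for this large difference.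

The single step removes a group with one hydrogen-bond acceptor and a double bond outside aromatic rings, and brings in a six-membered aromatic ring, so the compounds shown cannot tell whether the higher number follows the departure of dimethylcarbamoyl, the arrival of benzyl, or both. They also leave open how an acetyl, a methyl or a cyclohexylmethyl group, or an unsubstituted amine, on that ring nitrogen would read in this assay.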